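This account rests on a few compounds, and the source may have more. Where it says the series, first, only, none or still open, it means among the compounds named here.

In an assay on microsomes for inhibition of acyl-CoA:cholesterol acyltransferase (Oryctolagus cuniculus) (a lower number here means a stronger inhibitor, a higher number a weaker inhibitor), two compounds have been measured so far. Compound 1 `CC(C)c1cccc(C(C)C)c1NC(=O)NCC1(c2cccc([N+](=O)[O-])c2)CCCC1` gives 51 nM. Compound 2 `CC(C)c1cccc(C(C)C)c1NC(=O)NCC1(c2cccc(N)c2)CCCC1` gives 21 nM, the lowest of the two numbers, and its nearest neighbour is compound 1. Among the compounds with values here, the only measured step is a 2.4-fold lower number from compound 1 to compound 2 (0.39 log units; beyond the scatter), which is a modest shift.

Compound 3 `CC(C)c1cccc(C(C)C)c1NC(=O)NCC1(c2ccc(C(=O)O)cc2)CCCC1` has not yet been measured. It differs from compound 2 in one place: 4-carboxyphenyl in place of 3-aminophenyl on a saturated ring carbon. Within the data shown here, no measured step involves a carboxyl group or a move of the group to another position on that ring, so the one known step, a 2.4-fold lower number from compound 1 to compound 2 (0.39 log units; beyond the scatter), bears on this change only loosely: it shows that exchanging one group on that ring for another has so far moved the number modestly rather than dramatically. The exchange here is larger, both in what leaves and in what enters, so the expectation is a step of a 3.8-fold higher number from compound 2 to compound 3 (0.58 log units; beyond the scatter) in this assay, with wide uncertainty in either direction. Compound 3 is therefore expected to give about 80 nM in this assay, with a plausible range from 15 nM to 500 nM.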

Compound 3, half-maximal inhibitory concentration: 3100 nM
Compound 3: middle estimate off by 39-fold (1.59 log units), on the low side; the measured number lies above the stated range.
By their numbers in this assay, from the lowest: compound 2; then compound 1; then compound 3.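

In this assay, this position proves far less forgiving than the first two compounds suggested: the change brings a 150-fold higher number from compound 2 to compound 3 (2.17 log units; beyond the scatter) and, measured from the nitro compound, a 61-fold higher number from compound 1 to compound 3 (1.78 log units; beyond the scatter) as well. Compound 1 and compound 2 both give low numbers, while compound 3 stands far higher against either one, so this place on the saturated ring carbon does not accept every substituted phenyl group equally. No measurement here accounts for a rise of this size.

Compound 3 differs in two ways at once, in the group itself and in the 4 that replaces the 3 in its name, so the compounds shown cannot divide the rise between the carboxylic acid and its placement on the ring. As far as these compounds go, it also remains open whether a methyl ester or a primary amide in place of the carboxylic acid would give a number close to that of compound 3 or return toward that of compound 2.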